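A few compounds are considered here, and "the series" means these few. Any claim that something is new, unique, unknown or untested is made for them only; others in the source may bear on it.

Going by the values given here, compound 3 `C=Cc1cc(C(F)(F)F)cc(C(F)(F)F)c1` stands at the top of the numbers so far in an ADME assay for pharmacokinetics, read by HPLC, in phosphate buffer, with a stated time of 72 h, at pH 7.4, tested at 250 uM; a lower number here means that the compound disappears faster, a higher number that the compound lasts longer: compound 3 gives > 50 h, which is a limit of the assay and not a number, namely (the limit of > 50 h in this assay, at which 1 of the 3 values shown sits). In this assay compound 1 `C=CC(=O)Nc1cc(C(F)(F)F)cc(C(F)(F)F)c1` gives 4.2 h. Compound 2 `C=CS(=O)(=O)c1cc(C(F)(F)F)cc(C(F)(F)F)c1` gives < 0.017 h, again a limit of the assay rather than a number, namely (the limit of < 0.017 h in this assay, at which 1 of the 3 values shown sits). Both steps that reach compound 3 are large: an at least 11-fold higher number from compound 1 to compound 3 (1.07 log units; beyond the scatter) and an at least 2900-fold higher number from compound 2 to compound 3 (3.46 log units; beyond the scatter). Compound 4 `C#Cc1cc(C(F)(F)F)cc(C(F)(F)F)c1` has not yet been measured in this assay; it differs from compound 3 by ethynyl in place of vinyl on an aromatic carbon. Among the compounds with values here, no measured step exchanges one two-carbon hydrocarbon group for another, so neither step gives a direct size for this change; both only show that compound 3 sits at the limit > 50 h. Compound 4 is therefore expected to remain near that limit, estimated at 60 h with a range of 20 h to 200 h. The expected step, a step that the limit leaves unreadable from compound 3 to compound 4, is no change beyond the scatter, and most likely the assay again reports only a limit.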

Compound 4, half-life: > 50 h
Compound 4 ended at the assay's limit; the forecaster's own chance of this, stated with the estimate: 70%; the middle value does not contradict the limit.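

At this position on the shared core, ethynyl joins vinyl at the upper limit of this assay, so that limit no longer rests on compound 3 alone: the limit of > 50 h in this assay, at which 2 of the 4 values shown sit.

Compound 4 also stands clear of the two compounds that carry a carbonyl or sulfonyl group on the vinyl, with an at least 2900-fold higher number from compound 2 to compound 4 (3.46 log units; beyond the scatter) and an at least 11-fold higher number from compound 1 to compound 4 (1.07 log units; beyond the scatter). The step between the two hydrocarbon groups cannot be read, as both values are limits and not numbers.

Going by these compounds, whether the half-lives of compound 3 and compound 4 differ at all therefore stays open. Also open, on these data alone, is how other small groups on the same aromatic carbon, such as ethyl or a nitrile, would behave in this assay, and whether the two trifluoromethyl groups matter for the half-lives seen here.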